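A few compounds are considered here, and "the series" means these few. Any claim that something is new, unique, unknown or untested is made for them only; others in the source may bear on it.

Measured so far:

compound 1 `N#CC1=C(N)Oc2c(c3nc4ccccc4nc3c3ccccc23)C12C(=O)N(Cc1cnnn1-c1ccc(N)cc1)c1ccccc12` — > 50000 nM
compound 2 `Cc1ccc(-n2nncc2CN2C(=O)C3(C(C#N)=C(N)Oc4c3c3nc5ccccc5nc3c3ccccc43)c3ccccc32)cc1Cl` — > 50000 nM
compound 3 `N#CC1=C(N)Oc2c(N)cc3nc4ccccc4nc3c2C12C(=O)N(Cc1cnnn1-c1cccc(C(F)(F)F)c1)c1ccccc12` — 5400 nM

In a functional assay on A549 cells (Homo sapiens) for antiproliferative activity, read by MTT assay, with a stated time of 48 h (a lower number here means a stronger inhibitor, a higher number a weaker inhibitor), compound 1 gives > 50000 nM, which is a limit of the assay and not a number. Compound 2 likewise gives > 50000 nM, also a limit. Compound 3 gives 5400 nM and is the only one of the three with a number; the other two sit at the limit of > 50000 nM in this assay, at which 2 of the 3 values shown sit. Among the compounds with values here, the one step between measured compounds, a step that the two limits leave unreadable from compound 1 to compound 2, is unreadable for the same reason, so no measured step bears on the change to compound 4 `N#CC1=C(N)Oc2c(N)cc3nc4ccccc4nc3c2C12C(=O)N(Cc1cnnn1-c1c(F)cccc1F)c1ccccc12`. That change is 2,6-difluorophenyl in place of 3-(trifluoromethyl)phenyl on an aromatic nitrogen. With no readable precedent, no direction is expected beyond the scatter; the step of a 1.1-fold higher number from compound 3 to compound 4 (0.05 log units; within the scatter) is an estimate only. Compound 4 is estimated at 6000 nM, between 1500 nM and 25000 nM.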

Compound 4, half-maximal inhibitory concentration: > 50000 nM
Compound 4 gave a limit, no number (the forecaster's own chance of this, stated with the estimate: 25%); middle value at least 8.3-fold (0.92 log units) from the limit.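

With the core of compound 3 held fixed, the aryl group on the aromatic nitrogen proves to matter: 2,6-difluorophenyl in place of 3-(trifluoromethyl)phenyl gives an at least 9.2-fold higher number from compound 3 to compound 4 (0.96 log units; beyond the scatter) in this assay. Within the data shown here, this is the only readable step at this position, since the step between the two earlier limits cannot be read. Compound 4 gives a limit and not a number, so the full size of the step stays unknown, and the values now gather at one limit: the limit of > 50000 nM in this assay, at which 3 of the 4 values shown sit.

On these data alone, whether the loss follows the removal of trifluoromethyl or the arrival of the 2,6-difluoro pattern remains open, as this one step changes both. Plain phenyl or 3-fluorophenyl on the same nitrogen, with the core of compound 3, would separate the two.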